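The source may report more compounds than this note shows. Statements on the series, on what has been measured and on what is new or still open speak of the compounds shown alone.

compound 1 `O=C(N/N=C/c1ccc([N+](=O)[O-])cc1)Nc1ccc(Oc2ccnc3[nH]ccc23)cc1` gives 2100 nM
compound 2 `COc1ccc(/C=N/NC(=O)Nc2ccc(Oc3ccnc4[nH]ccc34)cc2)cc1` gives 4300 nM

In a functional assay on A549 cells (Homo sapiens) for antiproliferative activity, read by MTT assay, with a stated time of 72 h (a higher number here means a weaker inhibitor, a lower number a stronger inhibitor), compound 2 has the higher of the two numbers (4300 nM), which makes it the weaker inhibitor of the pair. Compound 3 (`CN(C)CCn1cccc1/C=N/NC(=O)Nc1ccc(Oc2ccnc3[nH]ccc23)cc1`) has not been measured yet. Its change (1-(2-(dimethylamino)ethyl)-1H-pyrrol-2-yl in place of 4-methoxyphenyl on a carbon with a double bond to nitrogen) sits on a carbon with a double bond to nitrogen, where 1-(2-(dimethylamino)ethyl)-1H-pyrrol-2-yl takes the place of 4-methoxyphenyl. Among the compounds with values here, only one measured step bears on this, and only indirectly. Methoxy in place of nitro on an aromatic carbon gave a modest change (a 2.0-fold higher number from compound 1 to compound 2 (0.31 log units; beyond the scatter)). That step altered one substituent, whereas here the whole group is exchanged, so the data give no firm direction. A modest step in this assay is still expected, leaning towards a lower number. The expected step (a 2.2-fold lower number from compound 2 to compound 3 (0.33 log units; beyond the scatter)) carries wide uncertainty. The estimated value for compound 3 is 2000 nM (range 400 nM to 8000 nM).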

Compound 3, half-maximal inhibitory concentration: "not active" (no number reported)
Nothing numeric was reported for compound 3; the estimate stays without a comparison.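

Within the data shown here, compound 3 is reported only as "not active", without a number, so no step from compound 2 to compound 3 can be read. In this assay the compounds shown leave open how far 1-(2-(dimethylamino)ethyl)-1H-pyrrol-2-yl in place of 4-methoxyphenyl moves the number. No supporting evidence bears on this result.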